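Dropping the methoxy from the pendant aryl ring

A few compounds are considered here, and "the series" means these few. Any claim that something is new, unique, unknown or untested is made for them only; others in the source may bear on it.

Compound 2 `COc1ccc(-c2[nH]c3ccc(OC)cc3c2/C=C(\C#N)S(=O)(=O)c2ccccc2)cc1` stands second highest of the three numbers measured in a functional assay on NCI-H23 cells (Homo sapiens) for inhibition, read by sulforhodamine B assay, with a stated time of 48 h (a lower number here means a stronger inhibitor of growth, a higher number a weaker inhibitor of growth), where compound 2 gives 946 nM. Compound 1 `COc1ccc(-c2[nH]c3ccccc3c2/C=C(\C#N)S(=O)(=O)c2ccccc2)cc1` is nearest: in this assay compound 1 gives 932 nM, and the step of a 1.0-fold higher number from compound 1 to compound 2 (0.01 log units; within the scatter) lies within the scatter. Compound 3 `CC(=O)/C(=C\c1c(-c2ccccc2)[nH]c2ccccc12)S(=O)(=O)c1ccccc1` is furthest; in this assay compound 3 gives 1600 nM, a value that still lies within the scatter of the value of compound 2.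

Compound 4 `COc1ccc2[nH]c(-c3ccccc3)c(/C=C(\C#N)S(=O)(=O)c3ccccc3)c2c1` differs from compound 2 by hydrogen in place of methoxy on an aromatic carbon. Among the compounds with values here, the only measured step of the same kind is the one from compound 1 to compound 2, a 1.0-fold higher number from compound 1 to compound 2 (0.01 log units; within the scatter), in which a methoxy entered on an aromatic carbon of the shared core, and the number did not move beyond the scatter. Within the data shown here, that methoxy sits on a different aromatic ring from the one changed here, so the bearing is indirect, but no measured step points to a move in either direction. The expected step is therefore a 1.0-fold higher number from compound 2 to compound 4 (0.00 log units; within the scatter), with no direction beyond the scatter. Compound 4 is estimated at 950 nM, with a range from 480 nM to 1900 nM.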

Compound 4, concentration for 50% growth inhibition: 8000 nM
Estimate against measurement, compound 4: 8.4-fold (0.93 log units) below, and the stated range ends below it.
By their numbers in this assay, from the lowest: compounds 1, 2 and 3 (each within the scatter of the next); then compound 4.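

In this assay, within the data shown here, the change from 4-methoxyphenyl to phenyl gives an 8.5-fold higher number from compound 2 to compound 4 (0.93 log units; beyond the scatter), so this methoxy, para to a large group, matters to the growth inhibition of compound 2 in a way the earlier compounds gave no sign of. Among these compounds, the only earlier step that added a methoxy, a 1.0-fold higher number from compound 1 to compound 2 (0.01 log units; within the scatter), changed another aromatic carbon of the shared core, and the two steps together show that, between compound 1, compound 2 and compound 4, the effect of a methoxy depends on the aromatic carbon that carries it. Nothing measured here accounts for the difference between these two positions.

The compounds shown leave open whether the methoxy itself is needed at this position or whether another group, such as a hydroxyl, a fluorine, an ethoxy or a dimethylamino group, would hold the number near that of compound 2. They also leave open whether the methoxy on the shared core would still make no difference to the number once the 4-methoxyphenyl has given way to phenyl.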